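A few compounds are considered here, and "the series" means these few. Any claim that something is new, unique, unknown or untested is made for them only; others in the source may bear on it.

Measured compounds:
compound 1 `Cc1ccc(-n2nncc2CN2C(=O)C3(C(C#N)=C(N)Oc4c(N)cc5nc6ccccc6nc5c43)c3ccccc32)cc1C` gives in a functional assay on HepG2 cells (Homo sapiens) for antiproliferative activity, read by MTT assay, with a stated time of 48 h; on this read-out higher numbers stand for weaker inhibition and lower numbers for stronger inhibition > 50000 nM
compound 2 `N#CC1=C(N)Oc2c(N)cc3nc4ccccc4nc3c2C12C(=O)N(Cc1cnnn1-c1ccc(F)c(Cl)c1)c1ccccc12` gives in this assay > 50000 nM

In this assay compound 1 returns only a limit, > 50000 nM. In the same assay compound 2 likewise returns only a limit, > 50000 nM. Going by the values given here, the one step among the measured pair, a step that the two limits leave unreadable from compound 1 to compound 2, therefore cannot be read in size or direction, since both ends sit at the assay's ceiling; this is summarised by the limit of > 50000 nM in this assay, at which 2 of the 2 values shown sit. Compound 2 thus stands at a limit, not at a number, and nothing more precise can be said of its place.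

The piece follows the step to compound 3 `COc1cc(-n2nncc2CN2C(=O)C3(C(C#N)=C(N)Oc4c(N)cc5nc6ccccc6nc5c43)c3ccccc32)c(OC)cc1Cl`, whose change from compound 2 is 4-chloro-2,5-dimethoxyphenyl in place of 3-chloro-4-fluorophenyl on an aromatic nitrogen. Among the compounds with values here, no measured step bears on this change with a readable size: the only measured step is unreadable because of the limit of > 50000 nM in this assay, at which 2 of the 2 values shown sit. On that basis no shift beyond the scatter is expected, and the estimated step that the limit leaves unreadable from compound 2 to compound 3 for compound 3 reflects that. Compound 3 is therefore estimated at 60000 nM in this assay, within a range from 20000 nM to 200000 nM, with a high chance that only a limit is again reported.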

Compound 3, half-maximal inhibitory concentration: > 50000 nM
Compound 3 gave a limit, no number (the forecaster's own chance of this, stated with the estimate: 80%); the middle value lies beyond the limit too.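

In this assay compound 3 gives > 50000 nM, which is a limit and not a number. The steps among compound 1, compound 2 and compound 3 therefore cannot be read in size or direction: the limit of > 50000 nM in this assay, at which 3 of the 3 values shown sit. The compounds shown leave open how strongly any of the three inhibits, and whether another group at this place would return a number in this assay.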